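Compound 3 and a swap on its nitrogen

The source may hold more compounds than are shown below. What is called first, only, known or untested is meant among the compounds shown, and "the series" means these compounds.

Among the compounds with values here, in a physicochemical assay for lipophilicity (on this read-out higher numbers stand for higher lipophilicity and lower numbers for lower lipophilicity), compound 3 `CCNC(=O)Nc1ccc(-c2nc(C(C)(C)S(C)(=O)=O)cc([C@]34CCOC[C@H]3C4)n2)cc1` gives 4.7, the highest of the three numbers measured so far. Compound 1 `CNCC(=O)Nc1ccc(-c2nc(C(C)(C)S(C)(=O)=O)cc([C@]34CCOC[C@H]3C4)n2)cc1` gives 4.3, and compound 2 `CC(C)(c1cc([C@@]23CCOC[C@@H]2C3)nc(-c2ccc(NC(=S)NCCO)cc2)n1)S(C)(=O)=O` gives 3.9, both lower than compound 3 by more than the usual scatter. The next molecule, compound 4 `CC(C)(c1cc([C@]23CCOC[C@H]2C3)nc(-c2ccc(NC(=S)NCCO)cc2)n1)S(C)(=O)=O`, has not yet been measured. It alters one place in compound 3: a group of 6 heavy atoms (3 carbon, 1 nitrogen, 1 oxygen, 1 sulfur; no ring) in place of a group of 5 heavy atoms (3 carbon, 1 nitrogen, 1 oxygen; no ring), on a nitrogen on an aromatic ring. Within the data shown here, only one measured step concerns a swap at this part of the molecule, a number 0.40 log units higher from compound 1 to compound 3 (beyond the scatter). That modest step shows that a change here can shift this assay, but it involves different groups, so it sets no size for this swap. A closer guide is compound 2, which carries the same entering group and gives 3.9. A clear step downward is therefore expected, estimated as a number 0.80 log units lower from compound 3 to compound 4 (beyond the scatter). For compound 4 the expected value is 3.9, with an estimated range from 3.6 to 4.2.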

Compound 4, partition coefficient: 3.9
The estimate for compound 4 equals the measured number at the digits printed; the measured number falls inside the stated range.
By their numbers in this assay, from the lowest: compounds 2 and 4 (each within the scatter of the next); then compound 1; then compound 3.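

Compound 4 has the same drawn configuration as compound 1 and compound 3, so in this assay the swap on the nitrogen on the aromatic ring can now be read in one place, with a number 0.80 log units lower from compound 3 to compound 4 (beyond the scatter) and a number 0.40 log units lower from compound 1 to compound 4 (beyond the scatter) as the two measured steps. Inverting both stereocentres leaves the number in place, with no change at the digits printed from compound 2 to compound 4 (within the scatter) in this assay for this pair of mirror images. The low number of compound 2 therefore goes with the entering group and not with the drawn configuration: the fact that compounds 2 and 4 differ only in the configuration as drawn.

The entering group differs from ethylcarbamoyl in its sulfur atom and in its hydrogen-bond donors and acceptors, and the compounds shown do not separate these differences. Also open, on these data alone, is how a propylcarbamoyl group or a simple amine on that nitrogen would read in this assay.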